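Compound 3 to compound 4: a small step expected

The source may hold more compounds than are shown below. What is called first, only, known or untested is meant among the compounds shown, and "the series" means these compounds.

Measured in a functional assay on SGC-7901 cells (Homo sapiens) for antiproliferative activity, read by MTT assay, with a stated time of 24 h (on this read-out higher numbers stand for weaker inhibition and lower numbers for stronger inhibition), so far:
- compound 1 `O=C(NNc1ccc(F)cc1)c1cccc(NS(=O)(=O)c2cnc(O)nc2O)c1` gives > 20000 nM (a limit)
- compound 2 `O=C(NNc1cccc(Cl)c1)c1ccccc1NS(=O)(=O)c1cnc(O)nc1O` gives 10800 nM
- compound 3 `O=C(NNc1ccccc1F)c1ccccc1NS(=O)(=O)c1cnc(O)nc1O` gives > 20000 nM (a limit)

In this assay compound 3 reads > 20000 nM and that is a limit, not a number. For the measured compounds named here, the series so far shows the limit of > 20000 nM in this assay, at which 2 of the 3 values shown sit, and compound 3 is one of those two. Only compound 2 gives a number, 10800 nM in the same read-out.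

In compound 4 `Cc1ccc(C(=O)NNC(=O)c2ccccc2NS(=O)(=O)c2cnc(O)nc2O)cc1` (4-methylphenyl)carbonyl takes the place of 2-fluorophenyl on an amine nitrogen (4-methylphenyl)carbonyl in place of 2-fluorophenyl on an amine nitrogen and the same difference reads (2-fluorophenyl)amino to ((4-methylphenyl)carbonyl)amino.

Going by the values given here, one measured step bears on this change, an at least 1.8-fold higher number from compound 2 to compound 3 (0.26 log units; that floor lies within the scatter) and it also concerns a group on an amine nitrogen. Among the compounds with values here, no measured compound carries a carbonyl at this place, so that step is only a loose guide. In this assay no step beyond the scatter is therefore expected, and no direction can be favoured with confidence. The estimated change is an at least 1.1-fold lower number from compound 3 to compound 4 (0.04 log units; that floor lies within the scatter) as a working expectation. Compound 4 is expected at about 18000 nM with an estimated range from 7000 nM to 40000 nM. A limit in place of a number would be no surprise.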

Compound 4, half-maximal inhibitory concentration: 15500 nM
Compound 4: middle estimate off by 1.2-fold (0.06 log units), on the high side; the measured number falls inside the stated range.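

In this assay compound 4 brings the first carbonyl-bearing group onto this amine nitrogen, whose other neighbour is an amide-type nitrogen, and it gives a number rather than a limit, level with the 3-chlorophenyl compound: a 1.4-fold higher number from compound 2 to compound 4 (0.16 log units; within the scatter). Against the 2-fluorophenyl group only a floor can be read, an at least 1.2-fold lower number from compound 3 to compound 4 (0.11 log units; that floor lies within the scatter), so the change from an aryl group to an aroyl group at this place shows no step beyond the scatter, and its true size stays unknown. Compound 3 and compound 1 each still stand as a limit and not a number: the limit of > 20000 nM in this assay, at which 2 of the 4 values shown sit.

All numbers so far lie close to that limit, so the compounds shown do not tell whether any group at this place can give a step beyond the scatter. From the compounds shown here alone, it also stays open whether the carbonyl or the 4-methyl group matters here, and how an unsubstituted benzoyl group, an acetyl group or a chain ending in an amine or a carboxylic acid would read at this nitrogen.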